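Replacing the urea link by a benzamide on a shared core

This account rests on a few compounds, and the source may have more. Where it says the series, first, only, none or still open, it means among the compounds named here.

Three measured compounds share one core and differ only in the aryl group hanging off the urea. Compound 1 `COc1cc(-c2nn(-c3cccc(NC(=O)Nc4ccc(Cl)c(Cl)c4)c3)cc2-c2ccncc2)ccc1Cl` gives 3080 nM in a functional assay on SF-539 cells (Homo sapiens) for inhibition, read by sulforhodamine B assay, with a stated time of 48 h; on this read-out higher numbers stand for weaker inhibition of growth and lower numbers for stronger inhibition of growth. Compound 2 `COc1cc(-c2nn(-c3cccc(NC(=O)Nc4cccc(C(F)(F)F)c4)c3)cc2-c2ccncc2)ccc1Cl` gives 2420 nM, and compound 3 `COc1cc(-c2nn(-c3cccc(NC(=O)Nc4ccc(Cl)c(C(F)(F)F)c4)c3)cc2-c2ccncc2)ccc1Cl` gives 6340 nM, the highest of the three numbers. The steps among them are small: a 1.3-fold lower number from compound 1 to compound 2 (0.10 log units; within the scatter), a 2.1-fold higher number from compound 1 to compound 3 (0.31 log units; beyond the scatter) and a 2.6-fold higher number from compound 2 to compound 3 (0.42 log units; beyond the scatter).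

Compound 4 `COc1cc(-c2nn(-c3cccc(NC(=O)c4ccccc4)c3)cc2-c2ccncc2)ccc1Cl` changes the linkage itself: phenyl in place of (4-chloro-3-(trifluoromethyl)phenyl)amino on a carbonyl carbon. None of the three measured steps touches this part of the molecule; each of them only swaps substituents on the outer ring, and each moves the number only modestly. The data therefore offer no direct guide, and the removal of the whole aminoaryl portion is a larger change than any measured one.

Compound 4 is expected to show a weaker result, with the step of a 1.4-fold higher number from compound 3 to compound 4 (0.15 log units; within the scatter) carrying wide uncertainty. The estimate for compound 4 in this assay is 9000 nM, within a range from 2500 nM to 30000 nM.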

Compound 4, concentration for total growth inhibition: 2880 nM
For compound 4 the middle estimate is 3.1-fold (0.49 log units) above the measured one, within the range that was stated.
By their numbers in this assay, from the lowest: compounds 2, 4 and 1 (each within the scatter of the next); then compound 3.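

In this assay the whole (4-chloro-3-(trifluoromethyl)phenyl)amino group can give way to a plain phenyl on the carbonyl carbon with no loss of growth inhibition: the change gives a 2.2-fold lower number from compound 3 to compound 4 (0.34 log units; beyond the scatter) and so a modest gain. The same kind of swap made from the other two ureas gives a 1.2-fold higher number from compound 2 to compound 4 (0.08 log units; within the scatter) and a 1.1-fold lower number from compound 1 to compound 4 (0.03 log units; within the scatter) and neither step leaves the scatter, so among these four compounds the outer aminoaryl portion is not needed to reach this level of activity. Nothing available explains why the shorter benzamide holds up so well.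

The compounds shown leave open whether chloro or trifluoromethyl on the new phenyl ring would move the number, as swaps on the outer ring of the ureas did. They also leave open what a methyl group or an amine on the same carbonyl carbon would do.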